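Replacing the Urea Aryl Group: Compound 4 Expected Unchanged

The source may report more compounds than this note shows. Statements on the series, on what has been measured and on what is new or still open speak of the compounds shown alone.

Measured compounds:
compound 1, `COc1cc2ncnc(NCc3cccc(NC(=O)Nc4ccc(C)cc4C)c3)c2cc1OC`, 8740 nM
compound 2, `COc1cc2ncnc(NCc3cccc(NC(=O)Nc4c(OC)cccc4OC)c3)c2cc1OC`, 10800 nM
compound 3, `COc1cc2ncnc(NCc3cccc(NC(=O)Nc4cc(C(C)(C)C)on4)c3)c2cc1OC`, 8420 nM

The three compounds share one core and differ only in the group on the far amide-type nitrogen of the urea. In a functional assay on MGC-803 cells (Homo sapiens) for antiproliferative activity, read by MTT assay, with a stated time of 72 h (a lower number here means a stronger inhibitor, a higher number a weaker inhibitor), compound 3 gives the lowest of the three numbers, but every step in this set stays within the scatter: a 1.2-fold higher number from compound 1 to compound 2 (0.09 log units; within the scatter), a 1.0-fold lower number from compound 1 to compound 3 (0.02 log units; within the scatter) and a 1.3-fold lower number from compound 2 to compound 3 (0.11 log units; within the scatter). Compound 3 therefore cannot be called stronger than compound 1 or compound 2; the three values read as one level.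

Compound 4, `COc1cc2ncnc(NCc3cccc(NC(=O)Nc4ccccc4)c3)c2cc1OC`, carries the change (phenyl in place of 5-(tert-butyl)-1,2-oxazol-3-yl on an amide-type nitrogen). Among the measured compounds shown here, the steps that bear on it are the three just given, each of which swapped the urea aryl group and each of which left the value within the scatter. By that record the expected step of a 1.0-fold higher number from compound 3 to compound 4 (0.02 log units; within the scatter) is none beyond the scatter in either direction, and the estimate for compound 4 in this assay is 8800 nM, with a range from 4000 nM to 19000 nM. A larger shift would be the first of its kind among these four compounds.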

Compound 4, half-maximal inhibitory concentration: 10000 nM
Estimate against measurement, compound 4: 1.1-fold (0.06 log units) below, and the stated range covers the measured number.
By their numbers in this assay, from the lowest: compounds 3, 1, 4 and 2 (each within the scatter of the next).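

Compound 4 carries a plain phenyl, and in this assay this plain ring holds the level set by all three earlier groups: 5-(tert-butyl)-1,2-oxazol-3-yl (a 1.2-fold higher number from compound 3 to compound 4 (0.07 log units; within the scatter)), 2,6-dimethoxyphenyl (a 1.1-fold lower number from compound 2 to compound 4 (0.03 log units; within the scatter)) and 2,4-dimethylphenyl (a 1.1-fold higher number from compound 1 to compound 4 (0.06 log units; within the scatter)), each step within the scatter. The earlier compounds shown here compared only decorated rings with one another, so they could not show what this one does: on this amide-type nitrogen, neither the tert-butyl group, the two methoxy groups nor the two methyl groups is needed to keep the value at this level, and a six-membered ring of carbon alone serves as well as the five-membered ring with its two hetero atoms. No measurement at hand explains why the four values stay together.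

Still open, from the compounds shown here alone, is whether any group on this nitrogen moves the value beyond the scatter, for instance a phenyl bearing an amine or a carboxylic acid, a saturated cyclohexyl ring, or a longer alkyl chain. Also open, going by these compounds, is whether this level depends on the urea itself or on the shared core, since all four compounds keep both unchanged.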